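From phenyl to pyridin-4-yl: an estimate for compound 3

The source may report more compounds than this note shows. Statements on the series, on what has been measured and on what is new or still open speak of the compounds shown alone.

Measured in an ADME assay on J774 cells (Mus musculus) for antiproliferative activity, with a stated time of 72 h; a higher number here means that more compound is needed for the effect, a lower number that less compound is needed:
- compound 1 `CCCCc1cc2c(=O)cc(C)[nH]c2cc1OCCOc1ccccc1`: 28000 nM
- compound 2 `CCCCc1cc2c(=O)c(-c3ccccc3)c(C)[nH]c2cc1OCCOc1ccccc1`: 23000 nM

Among the compounds with values here, the two values lie within the scatter of each other, so compound 2 stands level with compound 1, the only other compound measured. Compound 3 `CCCCc1cc2c(=O)c(-c3ccncc3)c(C)[nH]c2cc1OCCOc1ccccc1` differs from compound 2 as follows: pyridin-4-yl in place of phenyl on an aromatic carbon. In words, pyridin-4-yl takes the place of phenyl on an aromatic carbon. Within the data shown here, the one measured step that bears on this change filled the same carbon: a 1.2-fold lower number from compound 1 to compound 2 (0.09 log units; within the scatter). Among the measured compounds shown here, no measured step swaps these two rings, so the evidence is indirect, and no step beyond the scatter is expected in this assay. The expected step is a 1.0-fold lower number from compound 2 to compound 3 (0.02 log units; within the scatter). For compound 3 the estimated value is 22000 nM, with an expected range of 10000 nM to 45000 nM.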

Compound 3, half-maximal effective concentration: 23000 nM
Compound 3: the middle estimate sits 1.0-fold (0.02 log units) below what was measured; low and high end bracket the measured number.
By their numbers in this assay, from the lowest: compounds 2, 3 and 1 (each within the scatter of the next).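

Putting pyridin-4-yl in place of phenyl on this aromatic carbon gives no change at the digits printed from compound 2 to compound 3 (within the scatter) in this assay and so adds a ring nitrogen and a hydrogen-bond acceptor with no measurable difference. Against hydrogen at the same carbon, pyridin-4-yl gives a 1.2-fold lower number from compound 1 to compound 3 (0.09 log units; within the scatter) and thus reads as phenyl did, so neither ring separates from hydrogen here. No measurement at hand explains these level numbers. So far this carbon has carried only hydrogen and these two rings. As far as these compounds go, whether an amine, a carboxylic acid or a longer chain there would move the number beyond the scatter stays open.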